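Acetyl to chloro on the pyrimidine cap of compound 1

The source may hold more compounds than are shown below. What is called first, only, known or untested is meant among the compounds shown, and "the series" means these compounds.

Measured so far:
compound 1 `CC(=O)c1cnc(N2CCC(c3coc4c(N5CCc6cc(S(C)(=O)=O)ccc65)ncnc34)CC2)nc1` — 78 nM
compound 2 `CC(C)(C)OC(=O)N1CCC(c2csc3c(Nc4ccc(S(C)(=O)=O)cc4F)ncnc23)CC1` — 79 nM
compound 3 `CC(C)(C)OC(=O)N1CCC(c2c[nH]c3c(Nc4ccc(S(C)(=O)=O)cc4F)ncnc23)CC1` — > 1000 nM

In a functional assay on cells for agonist activity at Glucose-dependent insulinotropic receptor (Homo sapiens), read by a luciferase reporter, with a stated time of 4 h (a higher number here means that more compound is needed for the effect, a lower number that less compound is needed), compound 1 gives 78 nM. Compound 2 gives 79 nM in this assay, and the two values sit within the scatter of each other, so no order between them can be claimed. Compound 3 is reported only as a limit in this assay, > 1000 nM, and not as a number; this is the limit of > 1000 nM in this assay, at which 1 of the 3 values shown sits. Compound 1 thus stands at the lower of the two numbers shown, with compound 2 level with it and compound 3 at the limit.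

Compound 4 `CS(=O)(=O)c1ccc2c(c1)CCN2c1ncnc2c(C3CCN(c4ncc(Cl)cn4)CC3)coc12` has not been measured in this assay. It keeps the whole of compound 1 except at one place: chloro in place of acetyl on an aromatic carbon. Going by the values given here, no measured pair shows this exchange, so its size cannot be read from the data. Since compound 1 gives 78 nM, and the change is confined to one group on the pyrimidine, a small step toward a somewhat higher number is expected for compound 4, not far beyond the scatter, as a 1.5-fold higher number from compound 1 to compound 4 (0.19 log units; within the scatter). Compound 4 is therefore estimated at 120 nM, with a range from 40 nM to 400 nM.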

Compound 4, half-maximal effective concentration: 42 nM
Beside the measured number, compound 4's estimate is 2.9-fold (0.46 log units) above it, and the stated range covers the measured number.
By their numbers in this assay, from the lowest: compounds 4, 1 and 2 (each within the scatter of the next). At a limit, above all of these: compound 3.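

In this assay the exchange comes out as a 1.9-fold lower number from compound 1 to compound 4 (0.27 log units; within the scatter) and so acetyl and chloro on this carbon of the pyrimidine cannot be told apart. This aromatic carbon, two atoms from the ring nitrogen and para to a large group, carries a single chlorine as well as it carries the larger acetyl, which takes a double bond outside the aromatic rings and a hydrogen-bond acceptor with it when it leaves, so in this pair neither feature is required to keep the number within the scatter. No measurement shown gives a reason for this step.

From the compounds shown here alone, it remains open whether an amine, a carboxylic acid or a longer chain on the same carbon would stay within the scatter of compound 1 or move the number beyond it. Compound 2 and compound 3 differ from compound 1 in more than one place and so add nothing on this position, which also leaves open whether the exchange of acetyl for chloro would read the same on a different core.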